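This account rests on a few compounds, and the source may have more. Where it says the series, first, only, none or still open, it means among the compounds named here.

Compound 1, `O=c1c(O)c(-c2ccccc2)oc2cc(OCc3ccccc3Cl)cc(O)c12`, is a flavonol carrying a (2-chlorobenzyl)oxy group. In an ADME assay on Huh-5-2 cells (Homo sapiens) for cytotoxicity, read by WST assay, with a stated time of 3 days (on this read-out higher numbers stand for lower toxicity in this test and lower numbers for higher toxicity in this test), compound 1 gives > 100000 nM, which is a limit of the assay rather than a measured number, so compound 1 stands among the least toxic of the compounds here as far as the numbers go (the limit of > 100000 nM in this assay, at which 1 of the 2 values shown sits). Its closest measured neighbour is compound 2, `Cc1ccccc1COc1cc(O)c2c(=O)c(O)c(-c3ccccc3)oc2c1`, in which a methyl replaces the chloro on an aromatic carbon; in this assay compound 2 gives 17000 nM, and the step of an at least 5.8-fold lower number from compound 1 to compound 2 (0.76 log units; beyond the scatter) is the one that bears on the change discussed now.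

Compound 3, `Cc1cccc(COc2cc(O)c3c(=O)c(O)c(-c4ccccc4)oc3c2)c1`, has not been measured yet. It differs from compound 1 by 3-methylphenyl in place of 2-chlorophenyl on a saturated chain carbon bound to an oxygen on an aromatic ring. This resembles the step to compound 2 in that a chloro leaves and a methyl enters, but it reads 2-chlorobenzyl to 3-methylbenzyl rather than methyl in place of chloro on an aromatic carbon. A step in the same direction, downward, is therefore expected, probably of similar or somewhat smaller size, with a real chance that only a limit is reported again. The expected step is an at least 3.3-fold lower number from compound 1 to compound 3 (0.52 log units; beyond the scatter). Compound 3 is expected to give 30000 nM, within 10000 nM to 100000 nM.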

Compound 3, half-maximal cytotoxic concentration: 35000 nM
Beside the measured number, compound 3's estimate is 1.2-fold (0.07 log units) below it, and the stated range covers the measured number.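

In this assay, the place of the methyl on the benzyl ring goes with a real difference, which the earlier pair could not show: 3-methylphenyl in place of 2-methylphenyl gives a 2.1-fold higher number from compound 2 to compound 3 (0.31 log units; beyond the scatter), although the step is modest. Exchanging 2-chlorophenyl for 3-methylphenyl also lowers the number, giving an at least 2.8-fold lower number from compound 1 to compound 3 (0.45 log units; beyond the scatter), so both methyl compounds read lower than the chloro compound, and compound 3 reads higher than compound 2. The value of compound 1 is a limit of the assay and not a number, so the full size of each step starting from it stays unknown: the limit of > 100000 nM in this assay, at which 1 of the 3 values shown sits.

Between compound 1 and compound 3 the group and its place on the ring change together, so the compounds shown cannot separate what goes with losing the chloro from what goes with the new place. They also leave open how the number in this assay would respond to an amine or a carboxylic acid on the benzyl ring, groups that differ far more from chloro and methyl than these two differ from each other.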